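Swapping the Aryl Group on a Urea Linker

The source may report more compounds than this note shows. Statements on the series, on what has been measured and on what is new or still open speak of the compounds shown alone.

Compound 1 `CN(C)CCCNc1nc(-c2ccc(NC(=O)Nc3ccc(F)cc3)cc2)nc2c(Cl)c(Cl)sc12`: 980 nM
Compound 2 `CN(C)CCNc1nc(-c2ccc(NC(=O)Nc3ccc(F)cc3)cc2)nc2ccsc12`: 540 nM

Both compounds were tested in a functional assay on MDA-MB-231 cells (Homo sapiens) for cytotoxicity, read by MTT assay, with a stated time of 72 h; a lower number here means a stronger inhibitor, a higher number a weaker inhibitor. Compound 2 shows the lower of the two numbers at 540 nM, while compound 1 gives 980 nM; the gap between them lies within the usual scatter, so neither can be called the more potent. The two also differ in more than one place, so no single change can be tied to the small difference.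

Compound 3 `CN(C)CCNc1nc(-c2ccc(NC(=O)Nc3ccccc3Cl)cc2)nc2ccsc12` keeps the core of compound 2 and alters only the group on the urea nitrogen: 2-chlorophenyl in place of 4-fluorophenyl on an amide-type nitrogen. Nothing in the measured pair tells how this particular swap behaves, and the group that enters matches the one that leaves in size and in donor and acceptor count. The step from compound 2 to compound 3 in this assay is therefore expected to stay within the scatter, a 1.1-fold higher number from compound 2 to compound 3 (0.05 log units; within the scatter). Compound 3 is estimated at 600 nM, with a likely range from 250 nM to 1500 nM.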

Compound 3, half-maximal inhibitory concentration: 550 nM
Compound 3: the middle estimate sits 1.1-fold (0.04 log units) above what was measured; low and high end bracket the measured number.
By their numbers in this assay, from the lowest: compounds 2, 3 and 1 (each within the scatter of the next).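

In this assay, placing 2-chlorophenyl in place of 4-fluorophenyl on an amide-type nitrogen gives a 1.0-fold higher number from compound 2 to compound 3 (0.01 log units; within the scatter) and so leaves compound 2 and compound 3 indistinguishable. Unlike the first pair, which differed in more than one place, this pair differs only in the aryl group on the urea, giving the first direct reading at this position. Nothing measured here offers an explanation for how closely the two compounds match.

Both groups shown at this position are phenyl rings carrying one halogen, so it remains open how a plain phenyl, a pyridine ring, a methoxy-bearing phenyl or a small alkyl chain would read there. On these data alone, it is also open whether the same swap would read alike on the core of compound 1.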